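The source may report more compounds than this note shows. Statements on the series, on what has been measured and on what is new or still open speak of the compounds shown alone.

Compounds measured so far:
compound 1 `CCCCCCCOc1ccc(CCC(N)(CO)CO)cc1` with 0.049 mg/kg
compound 2 `CCCCCCCOc1ccc(CC[C@@](N)(CO)CCC)cc1` with 0.63 mg/kg
compound 3 `CCCCCCCOc1ccc(CC[C@](N)(CO)CCO)cc1` with 4.2 mg/kg

In a functional assay on the whole organism (spleen, spleen) with Rattus norvegicus as the target (a lower number here means that less compound is needed, a higher number that more compound is needed for the effect), compound 1 gives the lowest number of the three; the nearest is a 13-fold higher number from compound 1 to compound 2 (1.11 log units; beyond the scatter) and the furthest is an 86-fold higher number from compound 1 to compound 3 (1.93 log units; beyond the scatter). Compound 4 `CCCCCCCOc1ccc(CC[C@@](N)(CO)CCO)cc1` has not yet been measured in this assay. Its change from compound 1 is a group of 7 heavy atoms (4 carbon, 1 nitrogen, 2 oxygen; no ring) in place of a group of 6 heavy atoms (3 carbon, 1 nitrogen, 2 oxygen; no ring), on a saturated chain carbon, two bonds along the chain from an aromatic carbon. Compound 4 carries the same groups as compound 3 but the opposite arrangement at the stereocentre; the arrangement in compound 4 matches that found in compound 2.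

For the measured compounds named here, three measured steps bear on this. The step of an 86-fold higher number from compound 1 to compound 3 (1.93 log units; beyond the scatter) shows the same group entering in the other arrangement. The step of a 13-fold higher number from compound 1 to compound 2 (1.11 log units; beyond the scatter) shows a group of the same size, in the same arrangement as in compound 4, costing far less. The step of a 6.7-fold higher number from compound 2 to compound 3 (0.82 log units; beyond the scatter) separates the two. Since compound 4 shares its arrangement with compound 2, the expected step is closer to that seen for compound 2 than for compound 3: a clear rise, but smaller than an 86-fold higher number from compound 1 to compound 3 (1.93 log units; beyond the scatter). Compound 4 is therefore expected to give 0.3 mg/kg in this assay, with a range of 0.06 mg/kg to 1.5 mg/kg, which means an estimated step of a 6.1-fold higher number from compound 1 to compound 4 (0.79 log units; beyond the scatter).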

Compound 4, dose for 50% inhibition: 0.017 mg/kg
Beside the measured number, compound 4's estimate is 18-fold (1.25 log units) above it; the measured number lies below the stated range.
By their numbers in this assay, from the lowest: compound 4; then compound 1; then compound 2; then compound 3.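

The stereocentre at this saturated chain carbon turns out to matter more than any other change seen here, and a 250-fold lower number from compound 3 to compound 4 (2.39 log units; beyond the scatter) in this assay can be credited to that centre alone, because nothing else separates the pair: the fact that compounds 3 and 4 differ only in the configuration as drawn. In the better arrangement, the larger group carries no penalty, as a 2.9-fold lower number from compound 1 to compound 4 (0.46 log units; beyond the scatter) shows, so the high number of compound 3 was a matter of arrangement and not of swapping the 1-amino-2-hydroxy-1-(hydroxymethyl)ethyl group for a group of 7 heavy atoms. The hydroxy also counts, since with the arrangement held fixed, hydroxy in place of methyl gives a 37-fold lower number from compound 2 to compound 4 (1.57 log units; beyond the scatter), an effect that the earlier comparison of compound 2 with compound 3 could not separate from the change in arrangement.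

The compounds shown leave open whether the gain would survive with an amine or a carboxylic acid in place of this hydroxy, or with a longer chain carrying it. They also leave open whether the arrangement would matter as much for the methyl-ended chain of compound 2, and they do not show why either arrangement behaves as it does.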